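From 4-methoxyphenyl to 2-fluorophenyl on an amide-type nitrogen

The source may report more compounds than this note shows. Statements on the series, on what has been measured and on what is new or still open speak of the compounds shown alone.

In a functional assay on A549 cells (Homo sapiens) for inhibition, read by CCK-8 assay, with a stated time of 72 h, tested at 10 uM (a higher number here means more inhibition of growth at the concentration tested, a lower number less inhibition of growth), compound 2 `COc1ccc(NC(=O)C2(C(=O)Nc3ccc(Nc4ncc5cc(C(=O)N(C)C)n(C6CCCC6)c5n4)cc3)CC2)cc1` gives 78.5%. Among the measured compounds shown here, its only measured neighbour, compound 1 `Cc1cccc(NC(=O)C2(C(=O)Nc3ccc(Nc4ncc5cc(C(=O)N(C)C)n(C6CCCC6)c5n4)cc3)CC2)c1`, gives 86.1%, so the two cannot be told apart on these numbers. The next structure, compound 3 `CN(C)C(=O)c1cc2cnc(Nc3ccc(NC(=O)C4(C(=O)Nc5ccccc5F)CC4)cc3)nc2n1C1CCCC1`, keeps the shared core and alters a single group: 2-fluorophenyl in place of 4-methoxyphenyl on an amide-type nitrogen. In words, 2-fluorophenyl stands in place of 4-methoxyphenyl on an amide-type nitrogen. For the measured compounds named here, one measured step bears on this, made at the same kind of nitrogen, where one phenyl group replaced another: a number 7.6 percentage points lower from compound 1 to compound 2 (within the scatter). Going by the values given here, no measured compound carries 2-fluorophenyl, so this evidence is indirect and thin. In this assay, no step beyond the scatter is therefore expected. The step expected is a number 2.5 percentage points higher from compound 2 to compound 3 (within the scatter). The estimate for compound 3 is 81%, with an expected range of 67% to 92%.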

Compound 3, percent growth inhibition at one concentration: 88.6%
For compound 3 the middle estimate is 7.6 percentage points below the measured one, and the stated range covers the measured number.
By their numbers in this assay, from the lowest: compounds 2, 1 and 3 (each within the scatter of the next, the first and the last beyond it).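

In this assay, among the compounds shown here, putting 2-fluorophenyl in place of 4-methoxyphenyl on the amide-type nitrogen gives a number 10.1 percentage points higher from compound 2 to compound 3 (beyond the scatter) and is the only step at this position to clear the scatter, so the choice of substituted phenyl group here can shift growth inhibition. Set against 3-methylphenyl, the same 2-fluorophenyl group gives a number 2.5 percentage points higher from compound 1 to compound 3 (within the scatter) and the two cannot be told apart, so compound 2 is separated from compound 3 but not from compound 1. Nothing shown here offers an explanation for this difference.

On these data alone, all three compounds carry a substituted phenyl group on this nitrogen, so it remains open how a pyridine ring, a cyclohexyl group or a longer alkyl chain would behave there. Each value also comes from a single concentration, which leaves open how these compounds compare across a range of concentrations.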